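The source may hold more compounds than are shown below. What is called first, only, known or untested is meant among the compounds shown, and "the series" means these compounds.

Compounds measured so far in an assay on HEK293 cells for displacement of a labelled ligand from NPC1-like intracellular cholesterol transporter 1 (Homo sapiens); a lower number here means a stronger inhibitor, a higher number a weaker inhibitor:

compound 1, `CC(C)(C)c1ccc(C(=O)N2CCC3(CC2)C(=O)N(CC(=O)N2CCCCC2CCO)CN3c2ccccc2)cc1`, with 6100 nM;
compound 2, `CC(C)(C)c1ccc(C(=O)N2CCC3(CC2)C(=O)N(CC(=O)N2CCCCC2CO)CN3c2ccccc2)cc1`, with 11800 nM.

On these two numbers compound 2 stands at the higher end, but the difference to compound 1, a 1.9-fold higher number from compound 1 to compound 2 (0.29 log units; within the scatter), is within the scatter, so the two cannot be ordered. Compound 3, `CC(C)(C)c1ccc(C(=O)N2CCC3(CC2)C(=O)N(CC(=O)N2CCCC(C(N)=O)C2)CN3c2ccccc2)cc1`, carries a change at the same end of the molecule: 3-carbamoylpiperidin-1-yl in place of 2-(hydroxymethyl)piperidin-1-yl on a carbonyl carbon. Within the data shown here, no measured step covers this exchange. Among the measured compounds shown here, the only step on record, the one from compound 1 to compound 2, alters the pendant group on the piperidine and stays within the scatter, which suggests that changes in this region do not move the number much, though one step is thin evidence. Compound 3 is therefore expected to give a value close to that of compound 2, with a 1.2-fold lower number from compound 2 to compound 3 (0.07 log units; within the scatter) not beyond the scatter. The estimate for compound 3 in this assay is 10000 nM, with a range from 4000 nM to 25000 nM.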

Compound 3, half-maximal inhibitory concentration: 16900 nM
Beside the measured number, compound 3's estimate is 1.7-fold (0.23 log units) below it; the measured number falls inside the stated range.
By their numbers in this assay, from the lowest: compounds 1, 2 and 3 (each within the scatter of the next, the first and the last beyond it).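

The exchange to 3-carbamoylpiperidin-1-yl on the carbonyl carbon gives in this assay a 1.4-fold higher number from compound 2 to compound 3 (0.16 log units; within the scatter) and so does not separate these two compounds. Set against 2-(2-hydroxyethyl)piperidin-1-yl, the same group gives a 2.8-fold higher number from compound 1 to compound 3 (0.44 log units; beyond the scatter) as the first step here beyond the scatter, though a modest one, so this end of the molecule can move the number towards weaker inhibition. No supporting data bear on why either step comes out as it does.

Still open, on these data alone, is whether 2-carbamoylpiperidin-1-yl would read like its 3-carbamoyl isomer or like the two hydroxyalkyl groups. As far as these compounds go, it is also open whether an amine, a carboxylic acid or a chain longer than 2-hydroxyethyl on the piperidine would bring the number down.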